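Cyano in place of bromo on the same core

The compounds below may be only part of what the source reports. "The series", "measured", "known", "first", "only" and "open" are said of these compounds alone.

Of the compounds shown here, three built on one shared core have been measured so far; they differ only in the group carried on a six-membered aromatic ring of carbon only. Compound 1 `Cc1cccc(Cn2c(CN3CCN(C(=O)c4ccc([N+](=O)[O-])cc4)CC3)nc3ccccc32)c1` carries a nitro group there and in an assay on isolated protein for inhibition of aldehyde dehydrogenase 1A1 (Homo sapiens), read by spectrophotometry, tested at 10 uM (a higher number here means more inhibition at the concentration tested (going by the name of the read-out), a lower number less inhibition), compound 1 gives 24.3%. Compound 2 `COc1ccc(C(=O)N2CCN(Cc3nc4ccccc4n3Cc3cccc(C)c3)CC2)cc1` carries a methoxy group, and in this assay compound 2 gives 55.5%. Compound 3 `Cc1cccc(Cn2c(CN3CCN(C(=O)c4ccc(Br)cc4)CC3)nc3ccccc32)c1` carries a bromo group, and in this assay compound 3 gives 25.8%. Among the three numbers compound 3 stands second highest: its nearest neighbour is compound 1, within the scatter, and its furthest is compound 2, which lies beyond the scatter above it, as the step of a number 29.7 percentage points lower from compound 2 to compound 3 (beyond the scatter) shows.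

The next step leads to compound 4 `Cc1cccc(Cn2c(CN3CCN(C(=O)c4ccc(C#N)cc4)CC3)nc3ccccc32)c1`, with the change (cyano in place of bromo on an aromatic carbon). Going by the values given here, no measured step swaps in a cyano group, so only indirect guidance exists. The step of a number 1.5 percentage points higher from compound 1 to compound 3 (within the scatter) shows that exchanging one substituent on this ring for another can leave the number unchanged, while the steps of a number 31.2 percentage points higher from compound 1 to compound 2 (beyond the scatter) and a number 29.7 percentage points lower from compound 2 to compound 3 (beyond the scatter) show that it can also move the number by a large amount. Given that, compound 4 is expected to sit near compound 3, with a step of a number 2.2 percentage points higher from compound 3 to compound 4 (within the scatter), nothing beyond the scatter in either direction. Compound 4 is estimated at 28%, with a range from 10% to 50%.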

Compound 4, a percentage reported as inhibition, at one concentration (the size of the read-out at that concentration, not a potency): 20.8%
For compound 4 the middle estimate is 7.2 percentage points above the measured one; the measured number falls inside the stated range.
By their numbers in this assay, from the lowest: compounds 4, 1 and 3 (each within the scatter of the next); then compound 2.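

In this assay, cyano in place of bromo, on an aromatic carbon para to a large group, gives a number 5 percentage points lower from compound 3 to compound 4 (within the scatter), and cyano in place of nitro gives a number 3.5 percentage points lower from compound 1 to compound 4 (within the scatter), so cyano joins nitro and bromo as a third group with a number within the scatter of both. Cyano brings a triple bond and a hydrogen-bond acceptor that bromo lacks, yet these differences come with no step beyond the scatter between the two compounds. Methoxy alone stands apart among the four groups, as a number 34.7 percentage points lower from compound 2 to compound 4 (beyond the scatter) shows.

Nothing available here accounts for why compound 2 stands apart from the other three. Going by these compounds, whether an amine, a hydroxyl or a carboxylic acid on this ring would group with methoxy or with the other three remains open.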